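The compounds below may be only part of what the source reports. "The series", "measured", "known", "first", "only" and "open" are said of these compounds alone.

Working notes on the series. The three measured compounds share one core and differ only in the substituent on the carbonyl carbon. Compound 1 `CC(C)(C)C(=O)Nc1ccc(S(=O)(=O)Oc2ccccc2I)cc1` gives 6600 nM in a functional assay on MCF7 cells (Homo sapiens) for antiproliferative activity, read by sulforhodamine B assay, with a stated time of 48 h; a higher number here means a weaker inhibitor, a lower number a stronger inhibitor. Compound 2 `O=C(CCl)Nc1ccc(S(=O)(=O)Oc2ccccc2I)cc1` gives 2500 nM in this assay. Compound 3 `O=C(CCCCl)Nc1ccc(S(=O)(=O)Oc2ccccc2I)cc1` gives 6300 nM in this assay. The steps between them are small: a 2.6-fold lower number from compound 1 to compound 2 (0.42 log units; beyond the scatter); a 1.0-fold lower number from compound 1 to compound 3 (0.02 log units; within the scatter); a 2.5-fold higher number from compound 2 to compound 3 (0.40 log units; beyond the scatter). Compound 3 therefore stands second highest of the three numbers, within the scatter of compound 1 and separated from compound 2 only by a modest step.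

Compound 4 `O=C(NCC1CCCC1)Nc1ccc(S(=O)(=O)Oc2ccccc2I)cc1` differs from compound 3 by (cyclopentylmethyl)amino in place of 3-chloropropyl on a carbonyl carbon. Within the data shown here, no measured step bears directly on this change: the three steps compare chloroalkyl and tert-butyl groups on the carbonyl carbon, and none introduces a nitrogen or a ring there. What they show is that varying this position moved the numbers only modestly at most, and the group entering in compound 4 occupies the same place. The expectation is accordingly a step of the same order, direction uncertain, a 1.1-fold lower number from compound 3 to compound 4 (0.02 log units; within the scatter), rather than a large shift in either direction in this assay. Compound 4 is estimated at 6000 nM, with a range from 2000 nM to 18000 nM.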

Compound 4, half-maximal inhibitory concentration: 6600 nM
The estimate for compound 4 lay 1.1-fold (0.04 log units) below the measured number, and the stated range covers the measured number.
By their numbers in this assay, from the lowest: compound 2; then compounds 3, 1 and 4 (each within the scatter of the next).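

In this assay, (cyclopentylmethyl)amino in place of 3-chloropropyl on the carbonyl carbon gives a 1.0-fold higher number from compound 3 to compound 4 (0.02 log units; within the scatter) and the same group in place of tert-butyl gives no change at the digits printed from compound 1 to compound 4 (within the scatter) in the same assay, so a group with a nitrogen, a five-membered non-aromatic ring and a hydrogen-bond donor sits level with these two groups that have none of the three. Against chloromethyl the same group gives a 2.6-fold higher number from compound 2 to compound 4 (0.42 log units; beyond the scatter) and this modest step leaves compound 2 as the only one of the four set apart from the others by more than the scatter. No measured evidence accounts for the match among compound 1, compound 3 and compound 4 or for the separation of compound 2.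

Going by these compounds, it remains open whether the lower number of compound 2 belongs to the chloromethyl group itself, and how a plain methyl, a bromomethyl or a 2-chloroethyl group on the carbonyl carbon would compare. Also open, on these data alone, is how far this position stays flat for a (cyclohexylmethyl)amino group, a longer chain, or a chain ending in a carboxylic acid or an amine.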